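Allyl in place of butyl on a selenocyanate carbamate

The source may report more compounds than this note shows. Statements on the series, on what has been measured and on what is new or still open speak of the compounds shown alone.

Measured compounds:
- compound 1, `O=C(Nc1ccc([Se][Se]c2ccc(NC(=O)OCc3ccccc3)cc2)cc1)OCc1ccccc1`: 1800 nM
- compound 2, `CCCCOC(=O)Nc1ccc([Se]C#N)cc1`: 8100 nM

In a functional assay on HT-29 cells (Homo sapiens) for cytotoxicity, read by MTT assay, with a stated time of 72 h (a higher number here means a weaker inhibitor of growth, a lower number a stronger inhibitor of growth), compound 1 gives 1800 nM. In this assay compound 2 gives 8100 nM, which is the higher of the two numbers and lies beyond the scatter of the lower number of compound 1. Going by the values given here, compound 1 and compound 2 differ in several places at once, so their two values show only that compound 2 is the weaker inhibitor of growth of the pair, and nothing about any single change.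

Compound 3, `C=CCOC(=O)Nc1ccc([Se]C#N)cc1`, has not yet been measured. It differs from compound 2 in one place: vinyl in place of propyl on a saturated chain carbon bound to an oxygen next to a carbonyl group. This is a small shortening of the ester chain on the carbamate, with the rest of the molecule kept. Among the compounds with values here, no measured pair in this set isolates such a change, so there is no step from which to read its size. The step of a 1.0-fold lower number from compound 2 to compound 3 (0.01 log units; within the scatter) is expected to lie within the scatter, with no clear direction. Compound 3 is therefore estimated at 8000 nM, with a range from 3000 nM to 20000 nM.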

Compound 3, concentration for 50% growth inhibition: 24500 nM
Estimate against measurement, compound 3: 3.1-fold (0.49 log units) below; measured number above the stated range.
By their numbers in this assay, from the lowest: compound 1; then compound 2; then compound 3.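

Replacing butyl with allyl, the only place in which these two compounds differ, gives a 3.0-fold higher number from compound 2 to compound 3 (0.48 log units; beyond the scatter) in this assay and so makes compound 3 the weaker inhibitor of growth of this pair. Going by these compounds alone, compound 1 and compound 2 differ in several places at once, so this is the first step here to show that the chain on the carbamate oxygen is not a silent part of the molecule: a small exchange at this position moves the result beyond the scatter, though the step is modest in size. Nothing measured on these compounds accounts for the step.

The exchange removes a carbon and brings in a double bond together, so the step cannot say which of the two carries it, and a saturated propyl chain on the same oxygen would be the compound to separate them. From the compounds shown here alone, whether a longer chain such as hexyl would continue the trend in either direction remains open, as does whether the same exchange would have any comparable size on a core other than that of compound 2.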